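A few compounds are considered here, and "the series" means these few. Any claim that something is new, unique, unknown or untested is made for them only; others in the source may bear on it.

Measured compounds:
compound 1, `Cc1cc(=O)n(-c2ccccc2C(F)(F)F)nc1C(=O)Nc1ccc(Oc2ncnc3ccsc23)cc1`, 9230 nM
compound 2, `Cc1cc(=O)n(-c2ccc(F)cc2)nc1C(=O)Nc1ccc(Oc2ncnc3ccsc23)cc1`, 2110 nM

Both numbers come from a functional assay on HepG2 cells (Homo sapiens) for cytotoxicity, read by MTT assay, with a stated time of 72 h; a higher number here means a weaker inhibitor, a lower number a stronger inhibitor. Among the two compounds measured, compound 2 has the lower number, and its only neighbour is compound 1, which lies a 4.4-fold lower number from compound 1 to compound 2 (0.64 log units; beyond the scatter) away. So compound 2 stands as the stronger of the pair, with that step beyond the usual scatter.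

Compound 3, `Cc1ccc(-n2nc(C(=O)Nc3ccc(Oc4ncnc5ccsc45)cc3)c(C)cc2=O)c(C)c1`, has not yet been measured. It differs from compound 2 in one place: 2,4-dimethylphenyl in place of 4-fluorophenyl on an aromatic nitrogen. For the measured compounds named here, the only measured step that bears on this position is the one from compound 1 to compound 2, where a substituted phenyl on the same aromatic nitrogen was exchanged and the number moved by a 4.4-fold lower number from compound 1 to compound 2 (0.64 log units; beyond the scatter). Compound 3 carries two methyl groups on that phenyl, one of them ortho to the point of attachment, which brings it somewhat closer in shape to compound 1 than compound 2 is. On that single comparison, compound 3 is expected to give a somewhat higher number than compound 2, a step of a 1.7-fold higher number from compound 2 to compound 3 (0.22 log units; within the scatter), though the direction is uncertain. The estimated value for compound 3 in this assay is 3500 nM, with a range from 1200 nM to 10000 nM.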

Compound 3, half-maximal inhibitory concentration: 17900 nM
Compound 3: the middle estimate sits 5.1-fold (0.71 log units) below what was measured, outside the stated range (above it).
By their numbers in this assay, from the lowest: compound 2; then compounds 1 and 3 (each within the scatter of the next).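

In this assay, the group on the aromatic nitrogen matters in more than one direction: exchanging 4-fluorophenyl for 2,4-dimethylphenyl gives an 8.5-fold higher number from compound 2 to compound 3 (0.93 log units; beyond the scatter) and so leaves compound 2 with the lowest number of the three. The comparison with the trifluoromethyl compound gives a 1.9-fold higher number from compound 1 to compound 3 (0.29 log units; within the scatter), so two quite different substituted phenyl groups, 2-(trifluoromethyl)phenyl and 2,4-dimethylphenyl, cannot be told apart here. Among these three compounds, the two that carry a group at the 2-position of the phenyl ring both lie above compound 2, and none goes against this, but no measurement shown explains why the numbers fall this way.

The compounds shown leave open whether the group at the 2-position, the group at the 4-position or the two together set the number, since 2-methylphenyl and 4-methylphenyl are absent from this set. They also leave open how this position responds to a plain unsubstituted phenyl, or to a phenyl bearing an amine or a carboxylic acid.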